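Removing a Chloro Group from a Diaryl Urea

This account rests on a few compounds, and the source may have more. Where it says the series, first, only, none or still open, it means among the compounds named here.

Of the compounds shown here, two have been measured in an ADME assay on WI-38 cells (Homo sapiens) for cytotoxicity, read by MTT assay, with a stated time of 72 h; a higher number here means a weaker inhibitor, a lower number a stronger inhibitor. Compound 1 `Cn1ncnc1-c1cc(Oc2ccc(NC(=O)Nc3cccc(C(F)(F)F)c3)cc2F)ccn1` gives 22400 nM. Compound 2 `CCN(CC)CCn1cnnc1-c1cc(Oc2ccc(NC(=O)Nc3ccc(Cl)c(C(F)(F)F)c3)cc2F)ccn1` gives 6730 nM, the lowest of the two numbers; its nearest neighbour is compound 1, whose number stands higher by a margin beyond the usual scatter. Among the measured compounds shown here, compound 1 and compound 2 differ in more than one place, so their two values show only that the pair sits apart.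

Compound 3 `CCN(CC)CCn1cnnc1-c1cc(Oc2ccc(NC(=O)Nc3cccc(C(F)(F)F)c3)cc2F)ccn1` is still to be measured in this assay. It differs from compound 2 in a single point: hydrogen in place of chloro on an aromatic carbon. For the measured compounds named here, no measured step of exactly this kind is available, so the expectation leans on compound 1, which also lacks the chloro group and gives 22400 nM. A modest rise in the number is expected, a 1.8-fold higher number from compound 2 to compound 3 (0.25 log units; within the scatter). That rise would point in the direction of compound 1 without reaching it. Compound 3 is estimated at 12000 nM, with a range from 5000 nM to 30000 nM.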

Compound 3, half-maximal inhibitory concentration: 6920 nM
Estimate against measurement, compound 3: 1.7-fold (0.24 log units) above; the measured number falls inside the stated range.
By their numbers in this assay, from the lowest: compounds 2 and 3 (each within the scatter of the next); then compound 1.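

In this assay, replacing the chloro group of the 4-chloro-3-(trifluoromethyl)phenyl group with hydrogen gives a 1.0-fold higher number from compound 2 to compound 3 (0.01 log units; within the scatter), so this change, on the ring carbon ortho to a trifluoromethyl group, leaves no difference that can be told apart from the scatter. With the 3-(trifluoromethyl)phenyl group held constant, putting 4-(2-(diethylamino)ethyl)-4H-1,2,4-triazol-3-yl in place of 1-methyl-1H-1,2,4-triazol-5-yl gives a 3.2-fold lower number from compound 1 to compound 3 (0.51 log units; beyond the scatter), a step beyond the scatter, so in this series the measurable shift belongs to that exchange and not to the chloro exchange. No measurement is available that would explain either result.

The compounds shown leave open whether a different group at the chloro position, such as bromo or methoxy, would also leave the number within the scatter. They also leave open which part of the exchange at the other end of the molecule carries the step, a question that a 2-(dimethylamino)ethyl chain or a plain ethyl chain in place of the 2-(diethylamino)ethyl chain could help to separate.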